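The source may report more compounds than this note shows. Statements on the series, on what has been measured and on what is new or still open speak of the compounds shown alone.

Compound 2 `O=C1CC(c2nc(-c3ccccn3)no2)CN1c1ccc(F)cc1` carries a pyridin-2-yl group on the shared core. In an in vitro functional assay on HEK293-A cells for positive allosteric modulation of metabotropic glutamate receptor 5 (Homo sapiens), read by FLIPR and calcium flux (on this read-out lower numbers stand for an effect already at smaller amounts and higher numbers for an effect only at larger amounts of compound), compound 2 gives > 10000 nM, a limit of the assay rather than a number. Compound 1 `Cc1cccc(-c2noc(C3CC(=O)N(c4ccc(F)cc4)C3)n2)n1` differs from it by methyl in place of hydrogen on an aromatic carbon. In this assay compound 1 gives > 10000 nM, again a limit. The step that the two limits leave unreadable from compound 2 to compound 1 remains unreadable because of the limit of > 10000 nM in this assay, at which 2 of the 3 values shown sit. Compound 3 `Cc1ccc(N2CC(c3nc(-c4cccc(Cl)c4)no3)CC2=O)cc1` bears a 4-methylphenyl group; the difference between its core and that of compound 2 is not broken down here. In this assay compound 3 gives 630 nM. Compound 4 `Cc1ccc(N2CC(c3nc(-c4cccc(Cl)c4)no3)CC2=O)cc1C` differs from compound 3 by methyl in place of hydrogen on an aromatic carbon, the same kind of change as from compound 2 to compound 1, though here on a ring of carbon only, ortho to a methyl group, rather than next to a ring nitrogen. With the earlier step unreadable, the expected step is a 1.3-fold lower number from compound 3 to compound 4 (0.10 log units; within the scatter). That expectation rests on compound 3 alone at 630 nM. Compound 4 is expected to give 500 nM in this assay, between 150 nM and 2500 nM.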

Compound 4, half-maximal effective concentration: 310 nM
Beside the measured number, compound 4's estimate is 1.6-fold (0.21 log units) above it, within the range that was stated.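

On the 4-methylphenyl core, in this assay, methyl in place of hydrogen on an aromatic carbon gives a 2.0-fold lower number from compound 3 to compound 4 (0.31 log units; beyond the scatter), so 3,4-dimethylphenyl is a modest gain on this one core. The same kind of change from compound 2 to compound 1 cannot be read, because both values are limits of the assay and not numbers: the limit of > 10000 nM in this assay, at which 2 of the 4 values shown sit. Within the data shown here, the change has therefore been read on only one core, and this pair alone does not show that it carries over to another.

Going by these compounds, it remains open whether an ethyl group, a methoxy group or an amine in place of the added methyl would act like methyl. Also open, on these data alone, is whether the gain would appear on a core bearing a pyridin-2-yl group.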